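The compounds below may be only part of what the source reports. "The series", "measured", "known", "first", "only" and "open" are said of these compounds alone.

Measured in a functional assay on Hep 3B2 cells (Homo sapiens) for antiproliferative activity, read by MTT assay, with a stated time of 24 h; on this read-out lower numbers stand for stronger inhibition and higher numbers for weaker inhibition:
- Compound 1 `Cc1c(C(=O)Nc2c(F)cc(-c3cccc(F)c3)cc2F)nc2ccc(OC(F)(F)F)cc2c1O`: 85500 nM
- Compound 2 `COc1ccc2nc(C(=O)Nc3ccc(-c4ccccc4)cc3)c(C)c(O)c2c1`: 18100 nM
- Compound 3 `Cc1c(C(=O)Nc2ccc(-c3ccccc3)cc2)nc2ccccc2c1O`: 37200 nM

In this assay all three numbers are high. Compound 3, at 37200 nM, holds the middle place, with a higher number than compound 2 at 18100 nM and a lower number than compound 1 at 85500 nM.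

Compound 4 `Cc1c(C(=O)Nc2ccc(-c3ccccc3)cc2)nc2ccccc2c1C(=O)O` keeps the rest of compound 3 unchanged but has carboxy in place of hydroxy on an aromatic carbon, opposite the ring nitrogen and ortho to a methyl group (carboxy in place of hydroxy on an aromatic carbon). Within the data shown here, no measured compound carries carboxy, and no measured step changes this place. Among the measured compounds shown here, the only step available, a 2.1-fold higher number from compound 2 to compound 3 (0.31 log units; beyond the scatter), swaps methoxy for hydrogen elsewhere on the core. It is modest, so it bears on the new change only loosely, as a guide to how far one substitution has moved the numbers in this small set. The data fix no direction for the new change, so a step beyond the scatter is not expected, though a modest one either way remains possible. The expected result is a 1.2-fold lower number from compound 3 to compound 4 (0.07 log units; within the scatter). For compound 4 the estimated value is 32000 nM, with an expected range from 10000 nM to 100000 nM.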

Compound 4, half-maximal inhibitory concentration: 83500 nM
For compound 4 the middle estimate is 2.6-fold (0.42 log units) below the measured one; the measured number falls inside the stated range.
By their numbers in this assay, from the lowest: compound 2; then compound 3; then compounds 4 and 1 (each within the scatter of the next).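

In this assay, the place opposite the ring nitrogen and ortho to a methyl group proves open to change: with carboxy in place of hydroxy there is a 2.2-fold higher number from compound 3 to compound 4 (0.35 log units; beyond the scatter), a modest step toward weaker inhibition. Among these compounds, this is the first reading at this place, and it gives a direction for this one exchange, whereas the only earlier step, a 2.1-fold higher number from compound 2 to compound 3 (0.31 log units; beyond the scatter), concerned hydrogen in place of methoxy elsewhere on the shared core. Nothing measured here explains why the number moves with this exchange.

The compounds shown leave open how an amine, an ester or a longer chain at this place would compare with hydroxy and carboxy, and whether hydrogen there would shift the number at all. They also leave open whether the same exchange would give a step of similar size on the methoxy-bearing core of compound 2 or on the core of compound 1, so this single step cannot yet be taken as a pattern.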